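The source may report more compounds than this note shows. Statements on the series, on what has been measured and on what is new or still open speak of the compounds shown alone.

Measured so far in a physicochemical assay for lipophilicity, read by HPLC, at pH 7.4; on this read-out lower numbers stand for lower lipophilicity and higher numbers for higher lipophilicity:
compound 1 `CCOC(=O)C1=C(C)N/C(=C/c2cc(C)n(-c3cccc(C(F)(F)F)c3)c2C)C1=O` gives 3.4
compound 2 `CCOC(=O)C1=C(C)N/C(=C/c2cc(C)n(-c3ccc(F)cc3F)c2C)C1=O` gives 3
compound 3 `CCOC(=O)C1=C(C)N/C(=C/c2cc(C)n(-c3ccncc3)c2C)C1=O` gives 3.2

Compound 3 sits second highest of the three. The change a number 0.20 log units lower from compound 1 to compound 3 (within the scatter) and the change a number 0.20 log units higher from compound 2 to compound 3 (within the scatter) both stay within the scatter, so the three values cannot be ordered with confidence.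

Compound 4 `CCOC(=O)C1=C(C)N/C(=C/c2cc(C)n(-c3cccnc3)c2C)C1=O` is the next case: pyridin-3-yl in place of pyridin-4-yl on an aromatic nitrogen. Among the compounds with values here, no measured step exchanges one pyridyl for another; the two steps that end at compound 3 replace a substituted phenyl with pyridin-4-yl and were small. The whole series spans a narrow band in this assay. No step beyond the scatter is therefore expected; the expected change is no change at the digits printed from compound 3 to compound 4 (within the scatter). Compound 4 is estimated at 3.2, between 2.9 and 3.5.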

Compound 4, distribution coefficient: 2.1
Beside the measured number, compound 4's estimate is 1.10 log units above it, outside the stated range (below it).
By their numbers in this assay, from the lowest: compound 4; then compounds 2, 3 and 1 (each within the scatter of the next, the first and the last beyond it).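

In this assay, exchanging pyridin-4-yl for pyridin-3-yl on the aromatic nitrogen, with the same atoms joined differently, gives a clear separation (a number 1.10 log units lower from compound 3 to compound 4 (beyond the scatter)), so the read-out at this position depends on which pyridyl isomer is attached. Pyridin-3-yl also separates from both substituted phenyl groups (a number 0.90 log units lower from compound 2 to compound 4 (beyond the scatter); a number 1.30 log units lower from compound 1 to compound 4 (beyond the scatter)), whereas pyridin-4-yl stayed within the scatter of each. No measurement available here accounts for the difference between the two isomers.

The compounds shown leave open how pyridin-2-yl, or a pyridin-3-yl carrying an amine, would read at this position. As far as these compounds go, whether the gap between the two isomers recurs on another core also remains open.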